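The source may report more compounds than this note shows. Statements on the series, on what has been measured and on what is new or still open speak of the compounds shown alone.

Values in a functional assay on A549 cells (Homo sapiens) for cytotoxicity, read by MTT assay, with a stated time of 72 h; a higher number here means a weaker inhibitor, a lower number a stronger inhibitor
compound 1 `Cc1cccc(Nc2ncnc3oc(C)c(CO)c23)c1` gives 24000 nM
compound 2 `CCCNC(=O)c1c(C)oc2ncnc(Nc3cccc(C)c3)c12` gives > 1000000 nM (a limit of the assay, not a number)
compound 3 `Cc1cccc(Nc2ncnc3oc(C)c(C(=O)O)c23)c1` gives 100000 nM

Compound 1 has the lower of the two true numbers, and the gap to its nearest neighbour is a 4.2-fold higher number from compound 1 to compound 3 (0.62 log units; beyond the scatter) in size. The remaining steps, an at least 41-fold higher number from compound 1 to compound 2 (1.61 log units; beyond the scatter) and an at least 10-fold lower number from compound 2 to compound 3 (1.00 log units; beyond the scatter) as measured, also concern only the group that holds the hydroxymethyl place.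

Compound 4 `Cc1oc2ncnc(Nc3cccc(Br)c3)c2c1CO` keeps that hydroxymethyl and carries bromo in place of methyl on an aromatic carbon, meta to a large group, with bromo in place of methyl on an aromatic carbon as the counted difference. For the measured compounds named here, no measured step touches this place, so the large swings above bear on it only indirectly and give it neither size nor direction.

Compound 4 shares its hydroxymethyl with compound 1 at 24000 nM as the anchor, so only a small change is expected in this assay with no firm direction. The estimated step is a 1.3-fold lower number from compound 1 to compound 4 (0.12 log units; within the scatter) and may not exceed the scatter. For compound 4 the expected value is 18000 nM with an estimated range of 6000 nM to 55000 nM overall.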

Compound 4, half-maximal inhibitory concentration: 102000 nM
Compound 4: the middle estimate sits 5.7-fold (0.75 log units) below what was measured; the measured number lies above the stated range.
By their numbers in this assay, from the lowest: compound 1; then compounds 3 and 4 (each within the scatter of the next). At a limit, above all of these: compound 2.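

With hydroxymethyl held fixed, the step in this assay, a 4.3-fold higher number from compound 1 to compound 4 (0.63 log units; beyond the scatter), shows that the place meta to a large group is not silent, so the hydroxymethyl place is not the only one in this series that moves the number. The swap exchanges one heavy atom for one heavy atom, with no hydrogen-bond donors or acceptors and no net charge on either side, yet the change lies beyond the scatter and runs towards a weaker inhibitor. Nothing measured here gives a reason for this step.

From the compounds shown here alone, whether a chloro, a methoxy or an amine in this place would follow bromo or stay with methyl remains open. Also open, going by these compounds, is whether the same step would hold with a carboxy group in place of hydroxymethyl.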